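Trifluoromethyl for ethyl on the pendant aryl ring

The source may report more compounds than this note shows. Statements on the series, on what has been measured and on what is new or still open speak of the compounds shown alone.

Compound 3 `CCc1cccc(C2CNCC2C(=O)Nc2cc3cc[nH]c(=O)c3cc2Cl)c1` gives 4 nM in an assay on isolated protein for inhibition of Rho-associated protein kinase 2 (Homo sapiens), read by a luciferase reporter (on this read-out higher numbers stand for weaker inhibition and lower numbers for stronger inhibition), the lowest of the three numbers, though within the scatter of compound 2 `CC(C)c1cccc(C2CNCC2C(=O)Nc2cc3cc[nH]c(=O)c3cc2Cl)c1`, which gives 6 nM; compound 1 `O=C(Nc1cc2cc[nH]c(=O)c2cc1Cl)C1CNCC1c1ccc(F)cc1` gives 9 nM. The step of a 2.3-fold lower number from compound 1 to compound 3 (0.35 log units; beyond the scatter) is modest but beyond the scatter, whereas a 1.5-fold lower number from compound 2 to compound 3 (0.18 log units; within the scatter) and a 1.5-fold lower number from compound 1 to compound 2 (0.18 log units; within the scatter) are within it. Compound 4 `O=C(Nc1cc2cc[nH]c(=O)c2cc1Cl)C1CNCC1c1cccc(C(F)(F)F)c1` differs from compound 3 by trifluoromethyl in place of ethyl on an aromatic carbon, on an aromatic carbon meta to a large group. Among the measured compounds shown here, no measured step tests this exact exchange; the aryl substituent changes seen so far have moved this assay by at most a modest amount, and the isopropyl-to-ethyl exchange hardly at all. The expected step of a 1.5-fold higher number from compound 3 to compound 4 (0.18 log units; within the scatter) is therefore small, probably within the scatter, in either direction. Compound 4 is estimated at 6 nM, with a range of 2 nM to 18 nM.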

Compound 4, half-maximal inhibitory concentration: 4 nM
Estimate against measurement, compound 4: 1.5-fold (0.18 log units) above; low and high end bracket the measured number.
By their numbers in this assay, from the lowest: compounds 3, 4, 2 and 1 (each within the scatter of the next, the first and the last beyond it).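

At this aryl position in this assay, trifluoromethyl and ethyl cannot be told apart, with no change at the digits printed from compound 3 to compound 4 (within the scatter) and with a 1.5-fold lower number from compound 2 to compound 4 (0.18 log units; within the scatter) also inside the scatter. Alkyl groups are therefore not required here, since trifluoromethyl serves equally well. With a 2.3-fold lower number from compound 1 to compound 4 (0.35 log units; beyond the scatter) there are now two groups, 3-ethylphenyl and 3-(trifluoromethyl)phenyl, that stand beyond the scatter of the 4-fluorophenyl of compound 1, and no measurement shown gives a reason for this. Whether an amine or a carboxylic acid on this aromatic carbon would hold the number is open, as is the effect of a longer chain such as butyl.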